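Swapping dihydroxyphenyl for benzyl in a cell toxicity test

The source may hold more compounds than are shown below. What is called first, only, known or untested is meant among the compounds shown, and "the series" means these compounds.

Compound 1 (`Nc1ccc(Oc2ccccc2-c2ccc(S(=O)(=O)NCCNC(=O)Nc3cc(C(F)(F)F)cc(C(F)(F)F)c3)s2)cc1`) gives > 20000 nM as a limit of the assay, not a number
Compound 2 (`O=C(NCCNS(=O)(=O)c1ccc(-c2ccccc2Oc2ccc(O)c(O)c2)s1)Nc1cc(C(F)(F)F)cc(C(F)(F)F)c1`) gives 17100 nM as a measured number

Within the data shown here, in an ADME assay on HEK-293T cells (Homo sapiens) for cytotoxicity, read by CCK-8 assay, with a stated time of 48 h (on this read-out higher numbers stand for weaker inhibition and lower numbers for stronger inhibition), compound 2 gives 17100 nM as the only real number so far. For compound 1 the result > 20000 nM is a limit. Compound 3 (`O=C(NCCNS(=O)(=O)c1ccc(-c2ccccc2OCc2ccccc2)s1)Nc1cc(C(F)(F)F)cc(C(F)(F)F)c1`) differs from compound 2 in one place (benzyl in place of 3,4-dihydroxyphenyl on an oxygen on an aromatic ring) with benzyl in place of 3,4-dihydroxyphenyl on an oxygen on an aromatic ring. Among the measured compounds shown here, the one measured step at this place has only a floor for its size because of the limit of > 20000 nM in this assay, at which 1 of the 2 values shown sits, in these data. For the measured compounds named here, with an at least 1.1-fold lower number from compound 1 to compound 2 (0.06 log units; that floor lies within the scatter) as the only guide, no step beyond the scatter is expected in this assay in either direction. The estimated change is a 1.0-fold lower number from compound 2 to compound 3 (0.00 log units; within the scatter) and remains an expectation. For compound 3 the expected value is 17000 nM within an estimated range of 8000 nM to 30000 nM for repeat measurements.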

Compound 3, half-maximal inhibitory concentration: > 20000 nM
Compound 3 was reported as a limit; the forecaster's own chance of this, stated with the estimate: 40%; at least 1.1-fold (0.07 log units) between middle value and limit.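

In this assay, benzyl in place of 3,4-dihydroxyphenyl gives an at least 1.1-fold higher number from compound 2 to compound 3 (0.06 log units; that floor lies within the scatter). Among these compounds, this is the first group at this place with no hydrogen-bond donors or acceptors, and losing those of 3,4-dihydroxyphenyl produces no readable step beyond the scatter. Neither the full size of that step nor the step from compound 1 to compound 3 can be read, because the results stop at a limit: the limit of > 20000 nM in this assay, at which 2 of the 3 values shown sit.

On these data alone, whether any group on this oxygen can give a number clearly lower than that of compound 2 remains open. A carboxylic acid on the ring, or a longer chain in place of benzyl, could show whether this position can change the read-out at all.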